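The source may report more compounds than this note shows. Statements on the series, on what has been measured and on what is new or still open speak of the compounds shown alone.

Among the compounds with values here, in a functional assay on cells (Platelet, Homo sapiens) for inhibition (a higher number here means a weaker inhibitor, a lower number a stronger inhibitor), compound 2 `CCOC(=O)c1ccc(-c2nn(Cc3cccc(OC)c3)c3ccccc23)cc1` gives 260 nM, the lowest of the two numbers known so far. Compound 1 `CCOC(=O)c1cccc(-c2n[nH]c3ccccc23)c1` gives 5650 nM in this assay, a gap beyond the scatter; the two structures differ in more than one place, so the comparison says only what these two values show. Compound 3 `CCCCn1nc(-c2ccc(C(=O)OCC)cc2)c2ccccc21` has not yet been measured; it differs from compound 2 by propyl in place of 3-methoxyphenyl on a saturated chain carbon bound to an aromatic nitrogen. Within the data shown here, no matching step between measured compounds is available. The step of a 3.1-fold higher number from compound 2 to compound 3 (0.49 log units; beyond the scatter) is expected to be a moderate rise in the number, beyond the scatter. Compound 3 is therefore estimated at 800 nM, within 250 nM to 2500 nM.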

Compound 3, half-maximal inhibitory concentration: 670 nM
Compound 3: middle estimate off by 1.2-fold (0.08 log units), on the high side, within the range that was stated.
By their numbers in this assay, from the lowest: compound 2; then compound 3; then compound 1.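

Putting propyl in place of 3-methoxyphenyl on a saturated chain carbon bound to an aromatic nitrogen gives a 2.6-fold higher number from compound 2 to compound 3 (0.41 log units; beyond the scatter) in this assay. Within the data shown here, this is the first reading of a change at this place alone: the number rises beyond the scatter, yet the step is modest, so a chain with no ring still gives inhibition here.

As far as these compounds go, how an unsubstituted phenyl, a longer chain or an amine at this place would read stays open, as does which part of 3-methoxyphenyl matters. Nothing available explains the step.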